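The source may report more compounds than this note shows. Statements on the series, on what has been measured and on what is new or still open speak of the compounds shown alone.

Compound 1, `COc1cc(-c2cccc3nc(-c4ccc(F)cc4)oc23)cc(OC)c1OC`, in a functional assay on A549 cells (Homo sapiens) for antiproliferative activity, read by MTT assay, with a stated time of 48 h (a lower number here means a stronger inhibitor, a higher number a weaker inhibitor), gives 8700 nM.
Compound 2, `COc1cc(-c2cccc3nc(-c4ccc(Br)cc4)oc23)cc(OC)c1OC`, gives in this assay only a limit of the assay, > 25000 nM.
Compound 3, `COc1cc(-c2cccc3nc(-c4ccc(N)cc4)oc23)cc(OC)c1OC`, gives in this assay 720 nM.

Of the two plain numbers, compound 1 stands highest; compound 3 lies a 12-fold lower number from compound 1 to compound 3 (1.08 log units; beyond the scatter). Compound 4, `COc1cc(-c2cccc3nc(-c4ccc5cc[nH]c5c4)oc23)cc(OC)c1OC`, differs from compound 1 in one place: 1H-indol-6-yl in place of 4-fluorophenyl on an aromatic carbon. Going by the values given here, two measured steps bear on this. Bromo in place of fluoro gave an at least 2.8-fold higher number from compound 1 to compound 2 (0.45 log units; beyond the scatter), while amino in place of fluoro, bringing a hydrogen-bond donor, gave a 12-fold lower number from compound 1 to compound 3 (1.08 log units; beyond the scatter). The entering 1H-indol-6-yl also carries one hydrogen-bond donor but is a larger change than either, so the two steps point in opposite directions; a modest lowering, smaller than the amino step, is expected. Compound 4 is therefore estimated at 3000 nM in this assay, between 800 nM and 12000 nM, meaning a 2.9-fold lower number from compound 1 to compound 4 (0.46 log units; beyond the scatter).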

Compound 4, half-maximal inhibitory concentration: 55 nM
Beside the measured number, compound 4's estimate is 55-fold (1.74 log units) above it; the measured number lies below the stated range.
By their numbers in this assay, from the lowest: compound 4; then compound 3; then compound 1. At a limit, above all of these: compound 2.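

In this assay, replacing a substituted phenyl at this position with the two-ring 1H-indol-6-yl gives a 160-fold lower number from compound 1 to compound 4 (2.20 log units; beyond the scatter), and it goes well beyond the amino change, with a 13-fold lower number from compound 3 to compound 4 (1.12 log units; beyond the scatter). The earlier compounds shown here varied only one substituent on the phenyl ring, whereas this result shows that the whole group can be exchanged for a larger one with a strong gain. Compound 2 gives only a limit, so an at least 450-fold lower number from compound 2 to compound 4 (2.65 log units; beyond the scatter) is a bound: the limit of > 25000 nM in this assay, at which 1 of the 4 values shown sits.

As far as these compounds go, it remains open whether the indole's nitrogen hydrogen matters, which a 1-methylindol-6-yl group would test. Also open, from the compounds shown here alone, is whether another two-ring group, such as naphthalen-2-yl, would do the same.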